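Halophenyl exchange on the ethenyl chain: compound 2 to compound 3

The source may hold more compounds than are shown below. What is called first, only, known or untested is meant among the compounds shown, and "the series" means these compounds.

In a functional assay on PC-3 cells (Homo sapiens) for inhibition, read by MTT assay, with a stated time of 48 h (on this read-out lower numbers stand for stronger inhibition of growth and higher numbers for weaker inhibition of growth), compound 2 (`CN1CC[C@H](c2c(O)cc(O)c3c(=O)cc(/C=C/c4cccc(F)c4)oc23)[C@H](O)C1`) gives 7000 nM, the higher of the two numbers available. Compound 1 (`CN1CC[C@H](c2c(O)cc(O)c3c(=O)cc(/C=C/c4c(F)c(F)c(F)c(F)c4F)oc23)[C@H](O)C1`) gives 2000 nM. Compound 3 (`CN1CC[C@H](c2c(O)cc(O)c3c(=O)cc(/C=C/c4ccccc4Cl)oc23)[C@H](O)C1`) has not been measured. Its structure departs from compound 2 as follows: 2-chlorophenyl in place of 3-fluorophenyl on a double-bonded chain carbon bound to a double-bonded chain carbon. The same change reads as 2-(2-chlorophenyl)ethenyl in place of 2-(3-fluorophenyl)ethenyl.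

Among the measured compounds shown here, only one measured step bears on this change: a 3.5-fold higher number from compound 1 to compound 2 (0.54 log units; beyond the scatter). It is modest and exchanges a different pair of groups, so it gives only weak guidance here. No direct measurement covers 2-chlorophenyl, and no shift beyond the scatter is expected in this assay. The expected change is a 1.4-fold lower number from compound 2 to compound 3 (0.15 log units; within the scatter). For compound 3, the estimated value is 5000 nM, with an expected range of 2000 nM to 12000 nM.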

Compound 3, concentration for 50% growth inhibition: 17000 nM
Compound 3: middle estimate off by 3.4-fold (0.53 log units), on the low side, and the stated range ends below it.
By their numbers in this assay, from the lowest: compound 1; then compound 2; then compound 3.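

In this assay the halophenyl group on the ethenyl chain is not a silent exchange: 2-chlorophenyl in place of 3-fluorophenyl gives a 2.4-fold higher number from compound 2 to compound 3 (0.39 log units; beyond the scatter) and so weaker inhibition of growth, a change beyond the scatter. Set against the pentafluorophenyl group, the same 2-chlorophenyl group gives an 8.5-fold higher number from compound 1 to compound 3 (0.93 log units; beyond the scatter) as the widest gap in the series, so with the shared core held constant, the choice of halophenyl group alone spreads the numbers further than the first step showed. Nothing measured here accounts for these shifts.

Compound 3 differs from compound 2 in both the halogen and its place on the phenyl ring, so the compounds shown cannot separate these two changes. Also open, as far as these compounds go, is how a phenyl ring carrying a methoxy group or an amine instead of a halogen would read on this chain.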